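This account rests on a few compounds, and the source may have more. Where it says the series, first, only, none or still open, it means among the compounds named here.

Series notes, acid dissociation.

Compound 2 `COc1ccc(F)cc1CNCCCNc1ccnc2cc(Cc3ccc(F)cc3)ccc12` is the reference for the next step. In a physicochemical assay for acid dissociation, compound 2 gives 9.47. Compound 3 `COc1cccc(CNCCCNc2ccnc3cc(Cc4ccc(F)cc4)ccc23)c1O` stands level with it in this assay, where compound 3 gives 9.47. Compound 1 `COc1ccc(Oc2ccc3c(NCCCNCc4cc(F)ccc4OC)ccnc3c2)cc1` lies at the other end of the three numbers, and in this assay compound 1 gives 9.28; the step from compound 1 to compound 2 is a number 0.19 log units higher from compound 1 to compound 2 (within the scatter), so all three measured values sit inside the scatter of one another.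

The compound to be measured next is compound 4 `COc1ccc(F)cc1CNCCCNc1ccnc2cc(-c3cccc4ccccc34)ccc12`. Its difference from compound 2 is naphthalen-1-yl in place of 4-fluorobenzyl on an aromatic carbon.

Within the data shown here, two measured steps bear on this. The step from compound 1 to compound 2, a number 0.19 log units higher from compound 1 to compound 2 (within the scatter), swaps the group on the same aromatic carbon and is within the scatter. The step from compound 2 to compound 3, no change at the digits printed from compound 2 to compound 3 (within the scatter), alters the other end of the molecule and is likewise within the scatter. Neither shows a group on the aromatic carbon moving the read-out, so no step beyond the scatter is expected in this assay for compound 4; the expected step is a number 0.02 log units lower from compound 2 to compound 4 (within the scatter). Compound 4 is accordingly estimated at 9.45, with a range from 9.15 to 9.75.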

Compound 4, acid dissociation constant: 9.47
Estimate against measurement, compound 4: 0.02 log units below; low and high end bracket the measured number.
By their numbers in this assay, from the lowest: compounds 1, 2, 3 and 4 (each within the scatter of the next).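

Working notes on the aromatic carbon. In this assay, naphthalen-1-yl in place of 4-fluorobenzyl gives no change at the digits printed from compound 2 to compound 4 (within the scatter), and naphthalen-1-yl in place of 4-methoxyphenoxy gives a number 0.19 log units higher from compound 1 to compound 4 (within the scatter), so this position now has three groups on a constant remainder of the molecule, none separated from another by more than the scatter. The new group brings 2 six-membered aromatic rings of carbon only and 10 heavy atoms, against one such ring and 8 heavy atoms in 4-fluorobenzyl, and this difference in size and ring count leaves no readable trace in this read-out across the compounds shown. No supporting measurement bears on why the read-out stays within the scatter across these groups.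

The compounds shown leave open whether an amine or a carboxylic acid on this aromatic carbon would give a step beyond the scatter, since 4-fluorobenzyl and naphthalen-1-yl both carry no net charge and no hydrogen-bond donors or acceptors. Also open, on these data alone, is what a longer chain at the saturated carbons bound to the amine nitrogen would do to this assay.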